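Compound 1 and the pyrrolidin-2-yl change

This account rests on a few compounds, and the source may have more. Where it says the series, first, only, none or still open, it means among the compounds named here.

Three compounds have been measured in an ADME assay on the whole organism (strain Sprague-Dawley) for metabolic stability, with Rattus norvegicus as the target (on this read-out higher numbers stand for a longer-lived compound and lower numbers for a shorter-lived compound), so far:

Compound 1 `CN[C@@H](C)c1ccc(N2CC[C@H](NS(=O)(=O)c3ccc4cc(Cl)ccc4c3)C2=O)c(F)c1` gives 18 h
Compound 2 `CN(C)[C@@H]1CCc2cc(N3CC[C@H](NS(=O)(=O)c4ccc5cc(Cl)ccc5c4)C3=O)ccc21` gives 3.4 h
Compound 3 `CN1CCCC1c1ccc(N2CC[C@H](NS(=O)(=O)/C=C/c3ccc(Cl)s3)C2=O)c(F)c1` gives 1.4 h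

Compound 1 stands highest of the three, and compound 2 and compound 3 both lie below it by more than the scatter. The next compound to be measured, compound 4 `O=C1[C@@H](NS(=O)(=O)c2ccc3cc(Cl)ccc3c2)CCN1c1ccc(C2CCCN2)cc1F`, keeps the core of compound 1 and changes one group: pyrrolidin-2-yl in place of 1-(methylamino)ethyl on an aromatic carbon. The new group sits meta to a fluoro group and para to a large group.

Within the data shown here, no two measured compounds differ in one place only, so the data give no direct measure of such a step. The nearest hint is loose. Compound 3, which also holds a five-membered non-aromatic ring, gives 1.4 h in this assay but differs from compound 1 elsewhere as well. On this thin evidence, a moderate fall somewhat beyond the scatter is expected in this assay rather than no change.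

The estimated change is a 2.6-fold lower number from compound 1 to compound 4 (0.41 log units; beyond the scatter) and would be a drop. For compound 4 the expected half-life is 7 h, with an estimated range from 2.5 h to 18 h.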

Compound 4, half-life: 9 h
Estimate against measurement, compound 4: 1.3-fold (0.11 log units) below; the measured number falls inside the stated range.
By their numbers in this assay, from the lowest: compound 3; then compound 2; then compounds 4 and 1 (each within the scatter of the next).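

In this assay, among these compounds, the pair gives the first direct reading at this position: pyrrolidin-2-yl in place of 1-(methylamino)ethyl comes to a 2.0-fold lower number from compound 1 to compound 4 (0.30 log units; within the scatter) with the rest of the structure held constant. Compound 2 and compound 3 differ from compound 1 in more than one place and could not isolate this change, whereas here one five-membered non-aromatic ring replaces an open group with no shift that this read-out can separate from the scatter, on an aromatic carbon meta to a fluoro group and para to a large group. The data offer no measurement that accounts for this result.

The compounds shown leave open how a piperidin-2-yl group or a plain aminomethyl group would read at this place, and whether the two mirror-image forms of pyrrolidin-2-yl read alike, as the group in compound 4 has no defined stereocentre. They also leave open whether the same step would read alike on a compound carrying a hydrogen or a chloro group in place of the fluoro group.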